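The source may hold more compounds than are shown below. What is called first, only, known or untested is meant among the compounds shown, and "the series" means these compounds.

Compound 1 `COc1ccc(C(=O)c2ccc(OC)c3c2OC(C)(C)C=C3)c(NC(=O)CBr)c1`: 1210 nM
Compound 2 `COc1ccc(C(=O)c2ccc(OC)c3c2C=CC(C)(C)O3)c(NC(=O)CBr)c1`: 2460 nM
Compound 3 `COc1ccc(C(=O)c2ccc(OC)c3c2OC(C)(C)C=C3)c(NC(=O)CN)c1`: 270 nM

All three values come from a functional assay on A549 cells (Homo sapiens) for antiproliferative activity, read by MTT assay, with a stated time of 48 h; on this read-out higher numbers stand for weaker inhibition and lower numbers for stronger inhibition. In this set, compound 2 has the highest number at 2460 nM, so it is the weakest of the three, though the gap to compound 1 at 1210 nM lies only just beyond the scatter. Compound 3 has the lowest number at 270 nM.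

The next compound is compound 4 `COc1ccc(C(=O)c2ccc(OC)c3c2C=CC(C)(C)O3)c(NC(=O)CN)c1`, which keeps the core of compound 2 and changes one group: amino in place of bromo on a saturated chain carbon bound to a carbonyl carbon. The same exchange, amino in place of bromo, has been measured once, on the core of compound 1, and gave a 4.5-fold lower number from compound 1 to compound 3 (0.65 log units; beyond the scatter). Among the measured compounds shown here, this single modest step is the only direct guide, and no second pair shows whether it carries over to the core of compound 2. A step of similar size towards a lower number therefore seems the best guess, and the expected change is a 4.4-fold lower number from compound 2 to compound 4 (0.64 log units; beyond the scatter). For compound 4 the estimated value is 560 nM, with an expected range of 220 nM to 1400 nM.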

Compound 4, half-maximal inhibitory concentration: 420 nM
Compound 4: the middle estimate sits 1.3-fold (0.12 log units) above what was measured; low and high end bracket the measured number.
By their numbers in this assay, from the lowest: compounds 3 and 4 (each within the scatter of the next); then compound 1; then compound 2.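

Exchanging bromo for amino on a saturated chain carbon bound to a carbonyl carbon also pays off on the core of compound 2, giving a 5.9-fold lower number from compound 2 to compound 4 (0.77 log units; beyond the scatter) in this assay. Among the compounds shown here, until now, this exchange had been seen only on the core of compound 1, so the gain could have belonged to that one core alone. With a second pair, the change at this position proves to be of much the same size on both cores: the same change on two cores in this assay, a 4.5-fold lower number (0.65 log units; beyond the scatter) from compound 1 to compound 3 and a 5.9-fold lower number (0.77 log units; beyond the scatter) from compound 2 to compound 4, 1.3-fold (0.12 log units) apart, within the scatter of two such steps

The compounds shown carry only bromo or amino at this position, so they do not tell how a hydroxyl group, a dimethylamino group or a longer chain ending in an amine would fare. Nor do they tell why amino gives the lower number on both cores.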